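Cyclopropyl in place of a triazolyl group on the shared core

This account rests on a few compounds, and the source may have more. Where it says the series, first, only, none or still open, it means among the compounds named here.

Compound 3 `CNc1nc(NC2(C#N)CCCCC2)nc(-n2cnc(C)n2)n1` stands at the edge of what the assay can report: in an in vitro assay on Sf21 cells for inhibition of high affinity 3',5'-cyclic-AMP phosphodiesterase 7A (Homo sapiens) (on this read-out higher numbers stand for weaker inhibition and lower numbers for stronger inhibition), compound 3 gives > 5000 nM, which is a limit of the assay and not a number. Compound 1 `CNc1nc(NC2(C#N)CCCCC2)nc(-n2cccn2)n1` likewise gives only a limit, > 5000 nM. Among the compounds with values here, compound 2 `CNc1nc(Cl)nc(NC2(C#N)CCCCC2)n1` gives 1070 nM, the single finite value among the three. The steps read: an at least 4.6-fold lower number from compound 1 to compound 2 (0.66 log units; beyond the scatter) and an at least 4.6-fold higher number from compound 2 to compound 3 (0.66 log units; beyond the scatter), while a step that the two limits leave unreadable from compound 1 to compound 3 cannot be sized because the limit of > 5000 nM in this assay, at which 2 of the 3 values shown sit, hides both ends. Compound 4 `CNc1nc(NC2(C#N)CCCCC2)nc(C2CC2)n1` differs from compound 3 by cyclopropyl in place of 3-methyl-1H-1,2,4-triazol-1-yl on an aromatic carbon. Within the data shown here, no measured step swaps a five-membered aromatic ring for a small carbon ring; the closest guides are the exchange of a five-membered heteroaryl for chloro and its reverse, both at least modest and pointing toward lower numbers when the heteroaryl leaves. The step is therefore expected to be an at least 2.7-fold lower number from compound 3 to compound 4 (0.44 log units; beyond the scatter), a modest decrease. Compound 4 is estimated at 1800 nM, with a range from 500 nM to 6000 nM.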

Compound 4, half-maximal inhibitory concentration: 539 nM
The estimate for compound 4 lay 3.3-fold (0.52 log units) above the measured number, within the range that was stated.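

With compound 4, cyclopropyl joins chloro as a group that gives a finite reading at this position in this assay, so such a reading here does not depend on chloro: the exchange of chloro for cyclopropyl gives a 2.0-fold lower number from compound 2 to compound 4 (0.30 log units; within the scatter). Replacing either five-membered aromatic ring with cyclopropyl gives an at least 9.2-fold lower number from compound 3 to compound 4 (0.96 log units; beyond the scatter) and an at least 9.2-fold lower number from compound 1 to compound 4 (0.96 log units; beyond the scatter). Both of these steps start from a limit and not a number, and the step between compound 1 and compound 3 still cannot be read: the limit of > 5000 nM in this assay, at which 2 of the 4 values shown sit.

The compounds shown leave open how a dimethylamino group, a methoxy group or a longer chain such as n-butyl would read at this position. They also leave open whether a larger carbon ring, such as cyclohexyl, would read like cyclopropyl.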